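This account rests on a few compounds, and the source may have more. Where it says the series, first, only, none or still open, it means among the compounds named here.

From the compounds shown here alone, in a functional assay on CCRF-CEM cells (Homo sapiens) for cytotoxicity, read by sulforhodamine B assay, with a stated time of 48 h (a higher number here means that more compound is tolerated, a lower number that less compound is tolerated), three compounds have been measured and one remains open. Compound 1 `ClCc1cccc(Cn2cnc3ncnc(Cl)c32)c1` gives 60300 nM in this assay. Compound 2 `ClCc1cccc(Cn2cnc3c(Cl)ncnc32)c1` gives 7620 nM in this assay, so compound 1 tolerates a higher concentration than compound 2. The two are built from the same atoms joined differently; the difference between the two cores is not broken down here.

Compound 3 `ClCc1cccc(Cn2cnc3c(Cl)nc(Cl)nc32)c1` is reported in this assay only as a limit, > 100000 nM. Compound 3 arises from compound 2 by a single change, (chloro in place of hydrogen on an aromatic carbon), and this change brought an at least 13-fold higher number from compound 2 to compound 3 (1.11 log units; beyond the scatter). The step is known only as a lower bound because the limit of > 100000 nM in this assay, at which 1 of the 3 values shown sits, is where the reported value sits.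

Compound 4 `ClCc1cccc(Cn2cnc3nc(Cl)nc(Cl)c32)c1` is not yet measured. It arises from compound 1 by the same change, (chloro in place of hydrogen on an aromatic carbon), in surroundings described word for word as for the earlier pair. On the strength of that earlier step, an at least 13-fold higher number from compound 2 to compound 3 (1.11 log units; beyond the scatter), the step from compound 1 to compound 4 is expected to be a 3.3-fold higher number from compound 1 to compound 4 (0.52 log units; beyond the scatter). Since compound 1 already sits at 60300 nM, the expected value for compound 4 is 200000 nM, with a plausible range from 60000 nM to 600000 nM. It is likely that this assay will again report only a limit for compound 4.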

Compound 4, concentration lethal to 50% of the cells: 5490 nM
For compound 4 the middle estimate is 36-fold (1.56 log units) above the measured one; measured number below the stated range.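

In this assay, placing chloro in place of hydrogen on an aromatic carbon, between two ring nitrogen atoms, gave an 11-fold lower number from compound 1 to compound 4 (1.04 log units; beyond the scatter), meaning that less compound is tolerated after the change, and set beside the earlier pair this runs the opposite way: the same change on two cores in this assay, an at least 13-fold higher number (1.11 log units; beyond the scatter) from compound 2 to compound 3 and an 11-fold lower number (1.04 log units; beyond the scatter) from compound 1 to compound 4, at least 140-fold (2.15 log units) apart, beyond the scatter of two such steps With only these two pairs to go on, the result of this change on one core could not be carried over to the other core here, but the data do not show why the two cores part ways, nor which way the change would go on any further core. The gap between the two steps is known only as a lower bound, since compound 3 is reported as a limit and not as a number: the limit of > 100000 nM in this assay, at which 1 of the 4 values shown sits.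

The compounds shown carry only chloro or hydrogen at this ring carbon, so it remains open whether an amine, a methoxy group or a fluoro group there would follow the pattern of compound 4 or that of compound 3. From the compounds shown here alone, all four compounds also keep the same chloromethyl group, so it remains open how much of what is tolerated would shift if a methyl group or a hydroxymethyl group stood in its place.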